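Removing the methyl from selenium in compound 1

The compounds below may be only part of what the source reports. "The series", "measured", "known", "first", "only" and "open" are said of these compounds alone.

Compound 1, `COc1ccc(CNc2nc([Se]C)nc3ccccc23)cc1`: in a functional assay on HTB-54 cells (Homo sapiens) for cytotoxicity, read by MTT assay, with a stated time of 72 h (on this read-out higher numbers stand for weaker inhibition of growth and lower numbers for stronger inhibition of growth), compound 1 gives > 100000 nM, which is a limit of the assay and not a number.
Compound 2, `CCCCC[Se]c1nc([Se]CCCCC)c2cccnc2n1`: in this assay compound 2 gives 60500 nM.
Compound 3, `CSc1ccc(CNc2nc(SC)nc3ncccc23)cc1`: in this assay compound 3 gives 14800 nM.

Compound 1 therefore stands apart from the other two: it sits at the limit of > 100000 nM in this assay, at which 1 of the 3 values shown sits, so its growth-inhibiting concentration is not known as a figure, only as lying at that boundary. Compound 2 and compound 3 each carry a number, and of these two compound 3 shows the lower value.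

The next compound keeps everything of compound 1 except at one spot: hydrogen in place of methyl on a selenium, giving compound 4, `COc1ccc(CNc2nc([SeH])nc3ccccc23)cc1`. Among the compounds with values here, no pair among the measured compounds differs in only one place, so there is no measured step to set the size of this change. Compound 4 shares the whole remaining skeleton with compound 1, and with compound 1 resting at the assay boundary, the expectation is for a small move, if any, beyond the scatter in this assay.

On that basis compound 4 is estimated at 80000 nM, in a range from 20000 nM to 200000 nM. The step from compound 1 to compound 4 that this estimate implies is an at least 1.2-fold lower number from compound 1 to compound 4 (0.09 log units; that floor lies within the scatter), with a substantial chance that compound 4 is again reported only as a limit.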

Compound 4, concentration for total growth inhibition: 60900 nM
The estimate for compound 4 lay 1.3-fold (0.12 log units) above the measured number, and the stated range covers the measured number.
By their numbers in this assay, from the lowest: compound 3; then compounds 2 and 4 (each within the scatter of the next). At a limit, above all of these: compound 1.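

In this assay, the change from methyl to hydrogen on this selenium gives the first step among these compounds that can be read at a single place, an at least 1.6-fold lower number from compound 1 to compound 4 (0.21 log units; that floor lies within the scatter). It shows that the methyl can leave this selenium with the rest of the structure unchanged and that the compound then gives a number, whereas the value for compound 1 is only a limit of the assay, so the size of the step is known only as a floor: the limit of > 100000 nM in this assay, at which 1 of the 4 values shown sits. Since that floor lies within the scatter, the true step may be small or may be much larger, and the two values shown cannot settle which.

What the compounds shown leave open is how other groups at this selenium would read in this assay, such as an ethyl chain or a carboxylic acid-bearing chain in place of the methyl. They also leave open whether the same change from methyl to hydrogen would give a step of similar size on a compound whose starting value is a number rather than a limit.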